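Swapping Methyl for Fluoro on One Series

The source may report more compounds than this note shows. Statements on the series, on what has been measured and on what is new or still open speak of the compounds shown alone.

Three compounds share one core, a small saturated ring carrying two hydroxyl groups and an amine, attached to a benzene ring that differs only in what sits on it. Compound 1 `O[C@@H]1[C@@H](O)CN[C@H]1c1ccc(-c2ccccc2)cc1` carries a phenyl on the ring, compound 2 `O[C@@H]1[C@@H](O)CN[C@H]1c1ccccc1` a hydrogen there, and compound 3 `Cc1ccc([C@@H]2NC[C@H](O)[C@H]2O)cc1` a methyl. In an assay on isolated protein for inhibition of alpha-galactosidase (Coffea arabica), read by spectrophotometry, tested at 1000 uM (a higher number here means more inhibition at the concentration tested (going by the name of the read-out), a lower number less inhibition), compound 1 gives 0.3%, compound 2 gives 2.6% and compound 3 gives 0%. Compound 3 does not stand apart: the steps of a number 0.3 percentage points lower from compound 1 to compound 3 (within the scatter) and a number 2.6 percentage points lower from compound 2 to compound 3 (within the scatter) both lie within the scatter, as does a number 2.3 percentage points higher from compound 1 to compound 2 (within the scatter). None of the three shows meaningful inhibition at the concentration tested.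

Compound 4 `O[C@@H]1[C@@H](O)CN[C@H]1c1ccc(F)cc1` takes the step (fluoro in place of methyl on an aromatic carbon). Among the measured compounds shown here, the steps that bear on it are those that also change the group on that aromatic carbon: a number 0.3 percentage points lower from compound 1 to compound 3 (within the scatter) and a number 2.6 percentage points lower from compound 2 to compound 3 (within the scatter). Both were flat, whether the group was removed entirely or replaced by something much larger. A further change at that same position is therefore expected to leave the number where it is, with a step of a number 1 percentage points higher from compound 3 to compound 4 (within the scatter) that stays within the scatter. Compound 4 is estimated to give 1% in this assay, within a range from 0% to 8%.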

Compound 4, a percentage reported as inhibition, at one concentration (the size of the read-out at that concentration, not a potency): 16.6%
Beside the measured number, compound 4's estimate is 15.6 percentage points below it; measured number above the stated range.
By their numbers in this assay, from the lowest: compounds 3, 1 and 2 (each within the scatter of the next); then compound 4.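

Among the compounds shown here, until now this position looked indifferent to what sat on it, but in this assay fluoro is the first group to move the number beyond the scatter: a number 16.6 percentage points higher from compound 3 to compound 4 (beyond the scatter) and a number 14 percentage points higher from compound 2 to compound 4 (beyond the scatter) and also a number 16.3 percentage points higher from compound 1 to compound 4 (beyond the scatter) in this series. The flat steps among hydrogen, methyl and phenyl therefore did not mean that every group at this place gives the same result, and even exchanging one heavy atom for another can separate two compounds, although the counts of donors, acceptors and charge are the same for methyl and fluoro. Nothing available explains why fluoro differs from the other three groups here.

From the compounds shown here alone, it remains open whether this step belongs to fluoro alone or whether another single atom or small group, such as chloro, bromo, hydroxyl or an amine, would give a similar number at this position. Trifluoromethyl or methoxy in the same place would also help to show whether the step is specific to fluoro or part of a wider trend.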